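Notes on replacing pentyloxy with butylamino in the series

The source may report more compounds than this note shows. Statements on the series, on what has been measured and on what is new or still open speak of the compounds shown alone.

Measured in an ADME assay on HFF cells (Homo sapiens) for cytotoxicity, with a stated time of 8 days; on this read-out higher numbers stand for lower toxicity in this test and lower numbers for higher toxicity in this test:
Compound 1 `CNc1nc(N)nc2c1ncn2/C=C1/CC1(CO)CO` gives 265000 nM.
Compound 2 `CCCCCCCCSc1nc(N)nc2c1ncn2/C=C1/CC1(CO)CO` gives > 300000 nM, which is a limit of the assay and not a number.
Compound 3 `CCCCCOc1nc(N)nc2c1ncn2/C=C1/CC1(CO)CO` gives 259000 nM.

Compound 3 stands level with compound 1 within the scatter, with a 1.0-fold lower number from compound 1 to compound 3 (0.01 log units; within the scatter). Against compound 2 only a floor can be read, with an at least 1.1-fold lower number from compound 2 to compound 3 (0.06 log units; that floor lies within the scatter). The next step leads to compound 4 `CCCCNc1nc(N)nc2c1ncn2/C=C1/CC1(CO)CO`, which carries butylamino in place of pentyloxy on an aromatic carbon.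

All three measured steps fall on that same carbon. The exchange of methylamino for pentyloxy is the closest guide, and it stays within the scatter at a 1.0-fold lower number from compound 1 to compound 3 (0.01 log units; within the scatter). The exchange of methylamino for octylsulfanyl gives only a floor, an at least 1.1-fold higher number from compound 1 to compound 2 (0.05 log units; that floor lies within the scatter), which also lies within the scatter. Going by the values given here, no measured step varies the chain on an amino group, so that part remains open. No step beyond the scatter is therefore expected in this assay, and no direction is firmly indicated. The estimated step is a 1.1-fold lower number from compound 3 to compound 4 (0.03 log units; within the scatter). Compound 4 is expected to give 240000 nM, with an estimated range of 100000 nM to 300000 nM.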

Compound 4, half-maximal cytotoxic concentration: > 300000 nM
Compound 4 gave a limit, no number; the forecaster's own chance of this, stated with the estimate: 30%; middle value at least 1.2-fold (0.09 log units) from the limit.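

In this assay, butylamino in place of pentyloxy on this aromatic carbon gives an at least 1.1-fold higher number from compound 3 to compound 4 (0.06 log units; that floor lies within the scatter), so the change cannot be separated from compound 3 on this read-out. The series now also has a variation of the chain on the amino group, with propyl in place of hydrogen on the saturated chain carbon bound to the nitrogen giving an at least 1.1-fold higher number from compound 1 to compound 4 (0.05 log units; that floor lies within the scatter), and this too shows no readable separation. Compound 2 and compound 4 both stand at a limit of the assay rather than at a number, so the step between them cannot be read: the limit of > 300000 nM in this assay, at which 2 of the 4 values shown sit.

How far compound 2 and compound 4 lie past that limit stays unknown, so the effect of the chain and of the atom joining it to the aromatic carbon cannot be ranked among the compounds shown. From the compounds shown here alone, it also remains open whether a carboxylic acid, a piperidine or a longer chain on the amino group, such as octylamino, would give a step beyond the scatter at this position in this assay.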